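Swapping fluoro for bromo in compound 4

The source may report more compounds than this note shows. Statements on the series, on what has been measured and on what is new or still open speak of the compounds shown alone.

In a functional assay on SMMC-7721 cells (Homo sapiens) for cytotoxicity, read by MTT assay, with a stated time of 24 h (on this read-out lower numbers stand for stronger inhibition and higher numbers for weaker inhibition), the measured compounds are
Compound 1 `CN1C/C(=C\c2cccnc2)C(=O)/C(=C/c2ccccc2F)C1` gives 5420 nM
Compound 2 `O=C1/C(=C/c2cccnc2)CNC/C1=C\c1ccccc1F` gives > 20000 nM (a limit of the assay, not a number)
Compound 3 `O=C1/C(=C/c2cccnc2)CN(S(=O)(=O)c2ccc(F)cc2)C/C1=C\c1ccccc1F` gives 9900 nM

Within the data shown here, compound 3 has only one measured number to compare with, and the step of a 1.8-fold higher number from compound 1 to compound 3 (0.26 log units; within the scatter) places the two within the scatter of each other. Compound 4 `O=C1/C(=C/c2cccnc2)CN(S(=O)(=O)c2ccc(Br)cc2)C/C1=C\c1ccccc1F` differs from compound 3 in one place, and the difference is bromo in place of fluoro on an aromatic carbon on an aromatic carbon, para to a large group.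

Among the measured compounds shown here, no measured step changes this halogen, so the evidence is indirect. All three steps change the group on the ring amine nitrogen. The step of an at least 3.6-fold higher number from compound 1 to compound 2 (0.56 log units; beyond the scatter) goes beyond the scatter, while the floor of the step of an at least 2.0-fold lower number from compound 2 to compound 3 (0.30 log units; that floor lies within the scatter) lies within it. Those steps exchange a whole group, whereas bromo in place of fluoro exchanges a single atom on the far end of it. Even the larger exchange a 1.8-fold higher number from compound 1 to compound 3 (0.26 log units; within the scatter) stayed within the scatter, so no step beyond the scatter is expected in this assay and no direction can be favoured. The expected step is a 1.2-fold lower number from compound 3 to compound 4 (0.07 log units; within the scatter) and it should be read as no real change. The estimate for compound 4 is 8500 nM with an expected range from 3500 nM to 20000 nM in this read-out.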

Compound 4, half-maximal inhibitory concentration: 9100 nM
For compound 4 the middle estimate is 1.1-fold (0.03 log units) below the measured one, within the range that was stated.
By their numbers in this assay, from the lowest: compounds 1, 4 and 3 (each within the scatter of the next). At a limit, above all of these: compound 2.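

In this assay, among these compounds, the only step that changes this halogen is a 1.1-fold lower number from compound 3 to compound 4 (0.04 log units; within the scatter), so fluoro and bromo on this aromatic carbon, para to a large group, cannot be told apart here. The comparisons at the ring amine nitrogen also look much the same with bromo as with fluoro: a 1.7-fold higher number from compound 1 to compound 4 (0.23 log units; within the scatter) stays within the scatter, while an at least 2.1-fold lower number from compound 2 to compound 4 (0.34 log units; beyond the scatter) now goes beyond it, which the floor of the matching step to the fluoro compound did not. That step is still only a floor, and compound 2 has a limit, not a number: the limit of > 20000 nM in this assay, at which 1 of the 4 values shown sits.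

On these data alone, both halogens are single atoms, so it stays open whether a group built differently at the same place, such as a methoxy, an amine or a carboxylic acid, would move the number beyond the scatter. As far as these compounds go, whether having any halogen there matters at all, compared with a plain hydrogen, also stays open.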